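This account rests on a few compounds, and the source may have more. Where it says the series, first, only, none or still open, it means among the compounds named here.

Compound 1 `Cc1ccc(/C=N/NC(=O)COc2cccc3ccccc23)cc1` carries a 4-methylphenyl group on a carbon with a double bond to nitrogen. In a physicochemical assay for lipophilicity, measured as octanol-water partition (a higher number here means a more lipophilic compound, a lower number a more polar compound), compound 1 gives 4.49, the highest of the three numbers in hand. Compound 3 `O=C(COc1cccc2ccccc12)N/N=C/c1ccc([N+](=O)[O-])cc1` in this assay gives 3.97, and the step of a number 0.52 log units lower from compound 1 to compound 3 (beyond the scatter) accompanied nitro in place of methyl on an aromatic carbon. Among the measured compounds shown here, compound 2 `COc1ccc(/C=N/NC(=O)COc2cccc3ccccc23)cc1O` gives 3.48 in this assay; no single-place step links it to compound 1, so its number simply sits the furthest below.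

Compound 4 `O=C(COc1cccc2ccccc12)N/N=C/c1ccccc1Cl` differs from compound 1 by 2-chlorophenyl in place of 4-methylphenyl on a carbon with a double bond to nitrogen. For the measured compounds named here, only the step from compound 1 to compound 3 bears on this, and it was modest. Chlorine in place of methyl is a different kind of exchange from nitro in place of methyl, so a smaller shift is expected. The expected step, a number 0.01 log units higher from compound 1 to compound 4 (within the scatter), is estimated to stay within the scatter. The estimate for compound 4 in this assay is 4.5, with a range from 4.2 to 4.8.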

Compound 4, partition coefficient: 4.54
The estimate for compound 4 lay 0.04 log units below the measured number; the measured number falls inside the stated range.
By their numbers in this assay, from the lowest: compound 2; then compound 3; then compounds 1 and 4 (each within the scatter of the next).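

In this assay, the exchange on a carbon with a double bond to nitrogen gives a number 0.05 log units higher from compound 1 to compound 4 (within the scatter), so compound 4 and compound 1 cannot be told apart on this scale. The earlier step, a number 0.52 log units lower from compound 1 to compound 3 (beyond the scatter), lay beyond the scatter, and the new result shows that not every exchange of this kind moves the number that far. No measurement in hand accounts for this match between 2-chlorophenyl and 4-methylphenyl.

The exchange alters both the substituent and where it sits on the ring, so 4-chlorophenyl or 2-methylphenyl would be needed to tell those two changes apart. Going by these compounds, how an amine or a carboxylic acid on that ring would compare also remains open.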